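A few compounds are considered here, and "the series" means these few. Any claim that something is new, unique, unknown or untested is made for them only; others in the source may bear on it.

In a functional assay on DU-145 cells (Homo sapiens) for inhibition, read by trypan blue exclusion, with a stated time of 96 h (a higher number here means a weaker inhibitor of growth, a lower number a stronger inhibitor of growth), the three measured compounds give these numbers:

Compound 1 `Cc1ccc(S(=O)(=O)/C(=C/c2ccc(C)s2)C(=O)c2ccc(Br)cc2)cc1` gives 25000 nM.
Compound 2 `O=C(O)c1ccc(C(=O)/C(=C\c2ccc(Cl)c([N+](=O)[O-])c2)SCc2ccc(Cl)cc2)cc1` gives 1000 nM.
Compound 3 `Cc1ccc(S(=O)(=O)/C(=C/c2ccc(C)s2)C(=O)c2ccc(Cl)cc2)cc1` gives 50000 nM.

Compound 2 stands apart: compound 1 and compound 3 both give far higher numbers in this assay, and both gaps lie beyond the usual scatter. How the core of compound 2 differs from the core of compound 3 is not broken down here; the two differ in more than one place.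

Compound 1 and compound 3 differ in one place only, (bromo in place of chloro on an aromatic carbon), and that change gave a 2.0-fold lower number from compound 3 to compound 1 (0.30 log units; within the scatter), a step within the scatter.

Compound 4 `O=C(O)c1ccc(C(=O)/C(=C\c2ccc(Br)c([N+](=O)[O-])c2)SCc2ccc(Cl)cc2)cc1` has not been measured. It differs from compound 2 by bromo in place of chloro on an aromatic carbon. This is the same kind of change, though the surroundings differ: in compound 4 the bromo sits ortho to a nitro group as well as para to a large group, while in compound 1 it sits only para to a large group.

From compound 2 to compound 4 a step of about a 1.4-fold lower number from compound 2 to compound 4 (0.15 log units; within the scatter) is expected in this assay, because the like change gave a 2.0-fold lower number from compound 3 to compound 1 (0.30 log units; within the scatter). Compound 4 is therefore estimated at 700 nM, with a likely range from 250 nM to 2000 nM.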

Compound 4, concentration for 50% growth inhibition: < 1000 nM
Compound 4 ended at the assay's limit (the forecaster's own chance of this, stated with the estimate: 3%); the middle value is on the limit's open side.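

Compound 4 gives < 1000 nM in this assay, and this value is a limit of the assay, not a true number. Changing 4-chloro-3-nitrophenyl to 4-bromo-3-nitrophenyl therefore gave a number no higher from compound 2 to compound 4 (the limit leaves the size open), so this change did not raise the number on this core, but the result does not show how large the step is. Whether the change has the same size on both cores cannot be settled, so this pair neither confirms nor rules out that it carries over from one core to the other: the same change on two cores in this assay, a 2.0-fold lower number (0.30 log units; within the scatter) from compound 3 to compound 1 and a number no higher (the limit leaves the size open) from compound 2 to compound 4; the limit leaves it open whether they differ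

The compounds shown leave open how fluoro or iodo would read in place of the chloro or bromo on the core of compound 2. They also leave open what an amine in place of the nitro group, or an amide in place of the carboxylic acid, would do to the number in this assay.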